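The compounds below may be only part of what the source reports. "The series", "measured", "known", "first", "only" and "open" are said of these compounds alone.

Compound 3 `Fc1cccc(NC(=S)OCCc2ccccn2)c1` is the starting point here. In an ADME assay on MT4 cells (Homo sapiens) for cytotoxicity, read by MTT assay (a higher number here means that more compound is tolerated, a lower number that less compound is tolerated), compound 3 gives >= 100000 nM, which is a limit of the assay rather than a measured number. Compound 1 `S=C(Nc1ccccc1)OCCc1ccccn1` gives > 100000 nM in this assay, also a limit. Compound 2 `Cc1cccc(NC(=S)OCCc2ccccn2)c1` gives > 100000 nM in this assay, again a limit. Because all three sit at the limit of > 100000 nM in this assay, at which 2 of the 3 values shown sit, or (the limit of >= 100000 nM in this assay, at which 1 of the 3 values shown sits), the steps a step that the two limits leave unreadable from compound 1 to compound 2, a step that the two limits leave unreadable from compound 1 to compound 3 and a step that the two limits leave unreadable from compound 2 to compound 3 cannot be sized. Compound 4 `S=C(Nc1cccc(Cl)c1)OCCc1ccccn1` differs from compound 3 by chloro in place of fluoro on an aromatic carbon. With no readable step to lean on, the expected step is a number no higher from compound 3 to compound 4 (the limit leaves the size open), none beyond the scatter. Compound 4 is therefore estimated at 100000 nM, within a range from 50000 nM to 200000 nM.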

Compound 4, half-maximal cytotoxic concentration: 47000 nM
For compound 4 the middle estimate is 2.1-fold (0.33 log units) above the measured one; measured number below the stated range.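

In this assay, for the compounds shown here, chloro on this aromatic carbon brings the first change that can be read, with an at least 2.1-fold lower number from compound 3 to compound 4 (0.32 log units; beyond the scatter), with an at least 2.1-fold lower number from compound 2 to compound 4 (0.32 log units; beyond the scatter) and with an at least 2.1-fold lower number from compound 1 to compound 4 (0.32 log units; beyond the scatter). Less compound is therefore tolerated with chloro here than with fluoro, methyl or hydrogen, while the steps among those three cannot be read. Each size is only a floor because the compounds on the other side sit at limits, as compound 1 and compound 2 do: the limit of > 100000 nM in this assay, at which 2 of the 4 values shown sit.

From the compounds shown here alone, whether bromo or trifluoromethyl on this carbon would lower the number further stays open, as does the effect of an amine or a carboxylic acid there.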